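This account rests on a few compounds, and the source may have more. Where it says the series, first, only, none or still open, it means among the compounds named here.

Measured compounds in a functional assay on CHO cells for agonist activity at Free fatty acid receptor 1 (Homo sapiens), read by FLIPR and calcium flux; on this read-out lower numbers stand for an effect already at smaller amounts and higher numbers for an effect only at larger amounts of compound:
compound 1 `COc1cc(C)c(-c2cccc(COc3ccc(S(=O)(=O)CC(=O)O)cc3)c2)c(C)c1`: 57.5 nM
compound 2 `Cc1cc(OCC(C)C)cc(C)c1-c1cccc(COc2ccc(S(=O)(=O)CC(=O)O)cc2)c1`: 95.5 nM
compound 3 `COCCOc1cc(C)c(-c2cccc(COc3ccc(S(=O)(=O)CC(=O)O)cc3)c2)c(C)c1`: 126 nM

Compound 1 holds the lowest number of the three; the step to compound 2 is a 1.7-fold higher number from compound 1 to compound 2 (0.22 log units; within the scatter), the step to compound 3 is a 2.2-fold higher number from compound 1 to compound 3 (0.34 log units; beyond the scatter), and between those two a 1.3-fold higher number from compound 2 to compound 3 (0.12 log units; within the scatter).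

Compound 4 `CCOc1ccc(-c2cccc(COc3ccc(S(=O)(=O)CC(=O)O)cc3)c2)c(Cl)c1` is not yet measured. Against compound 1 the change is 2-chloro-4-ethoxyphenyl in place of 4-methoxy-2,6-dimethylphenyl on an aromatic carbon. Within the data shown here, none of the measured steps touches this change: all three vary only the group on a saturated chain carbon bound to an oxygen on an aromatic ring, and all stayed small. Among the measured compounds shown here, no measured pair speaks to swapping the whole ring, so the expectation rests on the narrow spread seen so far and carries a wide range. For compound 4 a modest rise in this assay is expected, a 2.6-fold higher number from compound 1 to compound 4 (0.42 log units; beyond the scatter), with an estimated 150 nM and a range from 40 nM to 600 nM.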

Compound 4, half-maximal effective concentration: 51.3 nM
Estimate against measurement, compound 4: 2.9-fold (0.47 log units) above; low and high end bracket the measured number.
By their numbers in this assay, from the lowest: compounds 4, 1, 2 and 3 (each within the scatter of the next, the first and the last beyond it).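

In this assay, 2-chloro-4-ethoxyphenyl in place of 4-methoxy-2,6-dimethylphenyl on this aromatic carbon gives a 1.1-fold lower number from compound 1 to compound 4 (0.05 log units; within the scatter), so this whole ring can be exchanged with the number staying within the scatter. The earlier steps shown here changed only the chain on the ring oxygen; this one shows that the two methyl groups are not needed for a number of this size when chlorine and ethoxy are present. No measurement shown bears on why the two rings read alike.

Chlorine, ethoxy and the loss of both methyl groups enter as one change, leaving the share of each open. On these data alone, how a ring carrying an amine or a nitrile, or a longer chain in place of ethoxy, would read in this assay also remains open.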